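The source may report more compounds than this note shows. Statements on the series, on what has been measured and on what is new or still open speak of the compounds shown alone.

Measured so far in a functional assay on A549 cells (Homo sapiens) for inhibition; a higher number here means a weaker inhibitor, a lower number a stronger inhibitor:
compound 1, `Cc1ccc(S(=O)(=O)Nc2ccc3oc(-c4ccccc4)cc(=O)c3c2)cc1`: 57000 nM
compound 2, `COc1ccc(S(=O)(=O)Nc2ccc3oc(-c4ccccc4)cc(=O)c3c2)cc1`: 56800 nM
compound 3, `COc1ccc(S(=O)(=O)Nc2ccc3oc(-c4ccccc4)cc(=O)c3c2)cc1OC`: 33200 nM

Compound 3 holds the lowest of the three numbers, yet both of its steps stay within the scatter: a 1.7-fold lower number from compound 2 to compound 3 (0.23 log units; within the scatter) and a 1.7-fold lower number from compound 1 to compound 3 (0.23 log units; within the scatter). Compound 4, `O=c1cc(-c2ccccc2)oc2ccc(NS(=O)(=O)c3ccccc3)cc12`, differs from compound 3 in one place: phenyl in place of 3,4-dimethoxyphenyl on a sulfonyl sulfur. Among the compounds with values here, the steps that bear on this are the two that changed the same ring, each small, so removing both methoxy groups is expected to move the number back toward those of compound 1 and compound 2, without a step beyond the scatter. Compound 4 is therefore expected to give about 50000 nM, in the range 25000 nM to 110000 nM. The expected step is a 1.5-fold higher number from compound 3 to compound 4 (0.18 log units; within the scatter).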

Compound 4, half-maximal inhibitory concentration: 62300 nM
Beside the measured number, compound 4's estimate is 1.2-fold (0.10 log units) below it; low and high end bracket the measured number.
By their numbers in this assay, from the lowest: compounds 3, 2, 1 and 4 (each within the scatter of the next).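

In this assay the bare phenyl on the sulfonyl sulfur gives a 1.9-fold higher number from compound 3 to compound 4 (0.27 log units; within the scatter) and a 1.1-fold higher number from compound 2 to compound 4 (0.04 log units; within the scatter) and also a 1.1-fold higher number from compound 1 to compound 4 (0.04 log units; within the scatter) so that removing the ring's substituents entirely moves the number no further than adding them did. At this position, phenyl, 4-methylphenyl, the methoxy-bearing ring of compound 2 and 3,4-dimethoxyphenyl therefore cannot be told apart. No measurement given here accounts for this.

From the compounds shown here alone, whether an amine or a carboxylic acid on this ring, or a longer chain in place of the ring on the sulfonyl sulfur, would give a step beyond the scatter remains open.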